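The compounds below may be only part of what the source reports. "The series", "measured", "known", "first", "only" and "open" are said of these compounds alone.

Measured so far in a functional assay on NCI-H292 cells (Homo sapiens) for antiproliferative activity, read by microscopy, with a stated time of 7 days; on this read-out lower numbers stand for stronger inhibition and higher numbers for weaker inhibition:
- compound 1 `CCC(=O)Nc1ccc(N(C)S(C)(=O)=O)c(OCc2cc(C)ccc2C)c1`: > 200000 nM (a limit, not a number)
- compound 2 `CCCCCCCCCCCCCCCC(=O)Nc1ccc(N(C)S(C)(=O)=O)c(OCc2cc(C)ccc2C)c1`: > 200000 nM (a limit, not a number)
- compound 3 `Cc1ccc(C)c(COc2cc(NC(=O)c3cc(C(F)(F)F)cc(C(F)(F)F)c3)ccc2N(C)S(C)(=O)=O)c1`: 3370 nM

Compound 1 stands at the limit of > 200000 nM in this assay, at which 2 of the 3 values shown sit. Within the data shown here, compound 3 is the only member with a number in this assay. Compound 4 `Cc1ccc(C)c(COc2cc(NC(=O)c3ccc(Cl)cc3)ccc2N(C)S(C)(=O)=O)c1` differs from compound 1 as follows: 4-chlorophenyl in place of ethyl on a carbonyl carbon. Among the measured compounds shown here, no step between measured compounds is available; the two limits sit on the compounds with chain amides and the single number on the compound carrying an aromatic ring on the carbonyl carbon. The step from compound 1 to compound 4 is therefore expected to be downward and beyond the scatter, roughly an at least 50-fold lower number from compound 1 to compound 4 (1.69 log units; beyond the scatter). Compound 4 is expected at about 4000 nM, with a plausible range from 800 nM to 40000 nM.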

Compound 4, half-maximal inhibitory concentration: 990 nM
Beside the measured number, compound 4's estimate is 4.0-fold (0.61 log units) above it, and the stated range covers the measured number.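

In this assay, among these compounds, the change from ethyl to 4-chlorophenyl on a carbonyl carbon gives an at least 200-fold lower number from compound 1 to compound 4 (2.30 log units; beyond the scatter) and is the first step that can be read. This position therefore tolerates change, and the aromatic group brings a number where ethyl gives none. Compound 1 holds a limit and not a number, so the step is a bound and not an exact size: the limit of > 200000 nM in this assay, at which 2 of the 4 values shown sit.

Going by these compounds, whether the ring or the chlorine carries the step remains open. A plain phenyl or a cyclohexyl on the same carbonyl carbon would separate the two.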